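The source may report more compounds than this note shows. Statements on the series, on what has been measured and on what is new or still open speak of the compounds shown alone.

Compound 1, `O=c1oc2ccccc2c(N2CCN(c3cccc(C(F)(F)F)c3)CC2)c1CO` — 31900 nM
Compound 2, `O=c1oc2ccccc2c(N2CCN(c3cccc(Cl)c3Cl)CC2)c1CO` — 8450 nM

Both numbers come from a functional assay on A-375 cells (Homo sapiens) for inhibition, read by MTT assay, with a stated time of 24 h; on this read-out lower numbers stand for stronger inhibition and higher numbers for weaker inhibition. Compound 2 gives the lowest of the two values, and compound 1 sits at a higher number, a gap beyond the usual scatter of this assay. The unmeasured compound 3, `COc1ccccc1N1CCN(c2c(CO)c(=O)oc3ccccc23)CC1`, is reached from compound 2 by a single change: 2-methoxyphenyl in place of 2,3-dichlorophenyl on an amine nitrogen in a ring. Within the data shown here, no measured pair shows this kind of change, so the size of the step in this assay is open. Among the measured compounds shown here, with only two measured compounds, both of which carry halogen-bearing aryl groups, the 2-methoxyphenyl group has no direct precedent here. The expected step from compound 2 to compound 3 is a 1.5-fold higher number from compound 2 to compound 3 (0.19 log units; within the scatter), a small move toward a higher number that may fall within the scatter. Compound 3 is therefore estimated at 13000 nM, with a plausible range from 3500 nM to 50000 nM.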

Compound 3, half-maximal inhibitory concentration: 20000 nM
The estimate for compound 3 lay 1.5-fold (0.19 log units) below the measured number; the range from low to high includes it.
By their numbers in this assay, from the lowest: compound 2; then compounds 3 and 1 (each within the scatter of the next).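

In this assay, among these compounds, the exchange of 2,3-dichlorophenyl for 2-methoxyphenyl on an amine nitrogen in a ring gives the first direct reading of a single change at this position: a 2.4-fold higher number from compound 2 to compound 3 (0.37 log units; beyond the scatter), a modest step beyond the scatter. It shows that an aryl group without halogen can stand here and that compound 3 still gives a measurable value of 20000 nM, though the number is higher than that of compound 2. Nothing at hand accounts for the size of this step.

The compounds shown leave open whether the step follows from losing the chlorine atoms or from gaining the methoxy group, since an unsubstituted phenyl or a 2-chlorophenyl in this place would be needed to separate the two. Going by these compounds, how a non-aromatic group such as cyclohexyl, or a benzyl group, would behave on this nitrogen also remains open.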